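Swapping the acetyl for ethoxy on compound 2

The compounds below may be only part of what the source reports. "The series", "measured", "known", "first", "only" and "open" are said of these compounds alone.

Compound 1 `CC(C)(C)c1ccc(C(=O)NCc2ccc(SC(F)(F)F)cc2)cc1`: 0.4 nM
Compound 2 `CC(=O)c1ccc(CNC(=O)c2ccc(C(C)(C)C)cc2)cc1`: 100 nM

Going by the values given here, in an assay on HeLa cells with Bile acid receptor (Homo sapiens) as the target, read by a luciferase reporter, with a stated time of 24 h (a higher number here means that more compound is needed for the effect, a lower number that less compound is needed), compound 2 gives the highest of the two numbers so far; the only other compound, compound 1, sits a 250-fold higher number from compound 1 to compound 2 (2.40 log units; beyond the scatter) away, so this one substituent change proved decisive. Compound 3 `CCOc1ccc(CNC(=O)c2ccc(C(C)(C)C)cc2)cc1` keeps the shared core and carries ethoxy in place of acetyl on an aromatic carbon. Among the compounds with values here, no measured step covers an ethoxy group, so the acetyl-to-ethoxy change is untested here. Given that the single known change at this position was large, a change of moderate size is expected, estimated as a 3.3-fold lower number from compound 2 to compound 3 (0.52 log units; beyond the scatter). For compound 3 the estimate is 30 nM, between 5 nM and 300 nM.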

Compound 3, half-maximal effective concentration: 160 nM
The estimate for compound 3 lay 5.3-fold (0.73 log units) below the measured number, and the stated range covers the measured number.
By their numbers in this assay, from the lowest: compound 1; then compounds 2 and 3 (each within the scatter of the next).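

In this assay ethoxy in place of acetyl gives a 1.6-fold higher number from compound 2 to compound 3 (0.20 log units; within the scatter) and so the two groups cannot be told apart at this position. The large gap to (trifluoromethyl)sulfanyl now holds against a second group, with a 400-fold higher number from compound 1 to compound 3 (2.60 log units; beyond the scatter) as the step from that group to ethoxy. Nothing available here explains this difference.

Going by these compounds, whether an amine, a carboxylic acid or a longer chain such as propoxy would behave like acetyl and ethoxy remains open. So does how trifluoromethoxy or methylsulfanyl would compare with (trifluoromethyl)sulfanyl.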